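The compounds below may be only part of what the source reports. "The series", "measured", "known", "first", "only" and "open" are said of these compounds alone.

Measured compounds:

Compound 1 `Cc1cc(C(=O)O)nn1Cc1cc(Br)ccc1OCc1ccc(Cl)c(C(F)(F)F)c1` gives 575 nM in an assay on CHO-K1 cells for displacement of a labelled ligand from prostaglandin E2 receptor EP1 subtype (Homo sapiens); a higher number here means a weaker inhibitor, a lower number a stronger inhibitor.
Compound 2 `Cc1cc(C(=O)O)nn1Cc1cc(Cl)ccc1OCc1ccc(Cl)cc1Cl` gives < 2000 nM in this assay; this is a limit of the assay, not a number.
Compound 3 `Cc1cc(C(=O)O)nn1Cc1cc(Cl)ccc1OCc1ccc(F)cc1F` gives < 2000 nM in this assay; this too is a limit.

Among the compounds with values here, compound 2 therefore stands only at a limit in this assay, and its place relative to compound 1 and compound 3 cannot be read from the numbers; the one measured step, a step that the two limits leave unreadable from compound 2 to compound 3, is likewise unreadable because of the limit of < 2000 nM in this assay, at which 2 of the 3 values shown sit.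

Compound 4 `Cc1cc(C(=O)O)nn1Cc1cc(F)ccc1OCc1ccc(Cl)cc1Cl` differs from compound 2 by fluoro in place of chloro on an aromatic carbon of a six-membered aromatic ring of carbon only, meta to a large group and para to a large group. Within the data shown here, no measured step bears on this change directly; the halogen at this position is bromo in compound 1 and chloro in compound 2 and compound 3, and the only numerical anchor is compound 1 with 575 nM.

The expectation is therefore a step of no readable size, a step that the limit leaves unreadable from compound 2 to compound 4, and compound 4 is estimated at 800 nM in this assay, within 250 nM to 2500 nM, with a fair chance that only a limit is reported.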

Compound 4, half-maximal inhibitory concentration: 355 nM
The estimate for compound 4 lay 2.3-fold (0.35 log units) above the measured number; the range from low to high includes it.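

No new step can be read from compound 2 to compound 4, because compound 2 stands only at a limit: the limit of < 2000 nM in this assay, at which 2 of the 4 values shown sit.

The compounds shown leave open the size of the change in this assay for fluoro in place of chloro on an aromatic carbon, with no pair among them differing only there and carrying two numbers.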